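Compound 4: 5-carboxyfuran-2-yl in place of thiophen-2-yl

A few compounds are considered here, and "the series" means these few. Any claim that something is new, unique, unknown or untested is made for them only; others in the source may bear on it.

In an ADME assay on microsomes from liver (Rattus norvegicus) for metabolic stability (on this read-out lower numbers stand for a shorter-lived compound and higher numbers for a longer-lived compound), compound 3 `Cn1nc2c(=O)n(CC3(O)CCN(Cc4ccc(-c5cccs5)cc4Cl)CC3)cnc2c1-c1ccc(CN)cc1` gives 1.38 h, clearly short of compound 1 `Cn1nc2c(=O)n(CC3(O)CCN(Cc4ccc(-c5cnco5)cc4Cl)CC3)cnc2c1-c1ccc(CN)cc1` at 3.85 h and within the scatter of compound 2 `Cn1nc2c(=O)n(CC3(O)CCN(Cc4ccc(C5=CCCC5)cc4Cl)CC3)cnc2c1-c1ccc(CN)cc1` at 2.33 h. Compound 4 `Cn1nc2c(=O)n(CC3(O)CCN(Cc4ccc(-c5ccc(C(=O)O)o5)cc4Cl)CC3)cnc2c1-c1ccc(CN)cc1` carries 5-carboxyfuran-2-yl in place of thiophen-2-yl on an aromatic carbon. Within the data shown here, two measured steps bear on this change: a 2.8-fold lower number from compound 1 to compound 3 (0.45 log units; beyond the scatter), and a 1.7-fold lower number from compound 2 to compound 3 (0.23 log units; within the scatter). Among the measured compounds shown here, both end at thiophen-2-yl, but no measured compound carries a carboxy group, so the evidence is indirect. Read in reverse, the first step points to a modest rise in this assay on leaving thiophen-2-yl. The expected step is a 2.5-fold higher number from compound 3 to compound 4 (0.40 log units; beyond the scatter). Compound 4 is estimated at 3.5 h, with an expected range of 1.5 h to 8 h.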

Compound 4, half-life: 1.25 h
Beside the measured number, compound 4's estimate is 2.8-fold (0.45 log units) above it; measured number outside the range, below it.
By their numbers in this assay, from the lowest: compounds 4, 3, 2 and 1 (each within the scatter of the next, the first and the last beyond it).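

In this assay, a carboxy-bearing ring at this position gives a 1.1-fold lower number from compound 3 to compound 4 (0.04 log units; within the scatter), so 5-carboxyfuran-2-yl and thiophen-2-yl cannot be told apart here. The same holds against cyclopent-1-en-1-yl, with a 1.9-fold lower number from compound 2 to compound 4 (0.27 log units; within the scatter), while 1,3-oxazol-5-yl stays clear of 5-carboxyfuran-2-yl, with a 3.1-fold lower number from compound 1 to compound 4 (0.49 log units; beyond the scatter), as it does of thiophen-2-yl. No measurement at hand accounts for these numbers. Still open, as far as these compounds go, is whether a carboxylic acid on the 1,3-oxazol-5-yl ring would keep the number of compound 1, and whether a primary amide or an aminomethyl group in place of the carboxy group would read differently.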